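Swapping the pyridine for a fluorinated methylphenyl

The source may hold more compounds than are shown below. What is called first, only, known or untested is meant among the compounds shown, and "the series" means these compounds.

Compound 3 `Cc1ccc([C@H](C)NC(=O)Cn2nnc3ccccc3c2=O)nc1` stands at the low end of the numbers seen so far. In an ADME assay on microsomes from liver (Homo sapiens) for metabolic stability (a lower number here means slower removal, a higher number faster removal of the compound), compound 3 gives a value that is only a limit of the assay, < 9.9 mL/min/kg. Compound 4 `Cc1ccc([C@H](C)NC(=O)Cn2nnc3ccccc3c2=O)c(F)c1` differs from it in one place: 2-fluoro-4-methylphenyl in place of 5-methylpyridin-2-yl on a saturated chain carbon bound to an amide-type nitrogen and a saturated chain carbon.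

Going by the values given here, three measured steps bear on this change. Compound 1 `Cc1cccc([C@H](C)NC(=O)Cn2nnc3ccccc3c2=O)c1` gives 11 mL/min/kg in this assay, and compound 2 `C[C@H](NC(=O)Cn1nnc2ccccc2c1=O)c1ccc(F)cc1` gives 31 mL/min/kg. Putting a fluorinated phenyl where a methylated phenyl sat gave a 2.8-fold higher number from compound 1 to compound 2 (0.45 log units; beyond the scatter). Putting the pyridine in place of either phenyl gave an at least 1.1-fold lower number from compound 1 to compound 3 (0.04 log units; that floor lies within the scatter) and an at least 3.1-fold lower number from compound 2 to compound 3 (0.49 log units; beyond the scatter). Compound 4 carries both a methyl and a fluorine on a phenyl ring, so the reverse of those pyridine steps points to a somewhat higher number, tempered by the methyl that compound 1 also carries. The step from compound 3 to compound 4 is therefore expected to be an at least 1.5-fold higher number from compound 3 to compound 4 (0.18 log units; that floor lies within the scatter). For compound 4 the estimated value in this assay is 15 mL/min/kg, likely between 8 mL/min/kg and 30 mL/min/kg.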

Compound 4, clearance: 28 mL/min/kg
Beside the measured number, compound 4's estimate is 1.9-fold (0.27 log units) below it, and the stated range covers the measured number.
By their numbers in this assay, from the lowest: compound 1; then compounds 4 and 2 (each within the scatter of the next). At a limit, below all of these: compound 3.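

In this assay, moving from the pyridine to a phenyl ring carrying both fluorine and methyl gives an at least 2.8-fold higher number from compound 3 to compound 4 (0.45 log units; beyond the scatter). As far as these compounds go, compound 3 sits at a limit of the assay, so the true size of this step remains unknown: the limit of < 9.9 mL/min/kg in this assay, at which 1 of the 4 values shown sits. Among the phenyl compounds, 2-fluoro-4-methylphenyl in place of 3-methylphenyl gives a 2.5-fold higher number from compound 1 to compound 4 (0.41 log units; beyond the scatter), while in place of 4-fluorophenyl it gives a 1.1-fold lower number from compound 2 to compound 4 (0.04 log units; within the scatter), so a methyl on the phenyl ring does not by itself keep a compound at the low end, and compound 4 stands with compound 2 rather than compound 1.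

The compounds shown leave open whether a fluorine on the pyridine ring would raise the number as well. They also leave open how a methoxy group or a chlorine in the fluorine's place would behave.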